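Bromo in place of hydrogen on the aryl ring

The compounds below may be only part of what the source reports. "The series", "measured", "known", "first", "only" and "open" are said of these compounds alone.

Measured compounds:
compound 1 `c1cncc(N2CC[C@@H]3CN[C@@H]3C2)c1` 260 nM
compound 2 `Clc1ccc(N2CC[C@@H]3CN[C@@H]3C2)cn1` 25 nM

Two compounds share a bicyclic amine core carrying an aryl substituent, and both have been tested in a functional assay on HEK293 cells for agonist activity at Neuronal acetylcholine receptor; alpha3/beta4 (Homo sapiens), read by FLIPR; on this read-out higher numbers stand for an effect only at larger amounts of compound and lower numbers for an effect already at smaller amounts. In this assay compound 1 gives 260 nM, the higher of the two numbers; compound 2 gives 25 nM. Going by the values given here, the one measured step is a 10-fold lower number from compound 1 to compound 2 (1.02 log units; beyond the scatter), brought about by a chloro in place of hydrogen on an aromatic carbon.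

Compound 3 `Brc1cncc(N2CC[C@@H]3CN[C@@H]3C2)c1` has not yet been measured. It differs from compound 1 by bromo in place of hydrogen on an aromatic carbon. Among the compounds with values here, the change resembles the one step on record in kind, a halogen entering for hydrogen on the aryl ring, so that step is the only guide, even though the halogen and the carbon it occupies are not the same. On that basis a lower number is expected for compound 3, of a size comparable to, or somewhat smaller than, the step to compound 2: a 4.3-fold lower number from compound 1 to compound 3 (0.64 log units; beyond the scatter). The estimate for compound 3 in this assay is 60 nM, with a range from 20 nM to 200 nM.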

Compound 3, half-maximal effective concentration: 950 nM
Beside the measured number, compound 3's estimate is 16-fold (1.20 log units) below it; measured number above the stated range.
By their numbers in this assay, from the lowest: compound 2; then compound 1; then compound 3.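

In this assay, bromo on the aromatic carbon two atoms from the ring nitrogen gives a 3.7-fold higher number from compound 1 to compound 3 (0.56 log units; beyond the scatter) and so runs the opposite way to a 10-fold lower number from compound 1 to compound 2 (1.02 log units; beyond the scatter) seen with the chloro change. A halogen in place of hydrogen on this aryl ring therefore does not lower the number as a general rule, and the direction of the step differs between two changes that vary in both the halogen and the carbon it occupies, so that these two differences cannot be told apart here. No measurement shown bears on why bromo at this place gives the higher number.

The compounds shown leave open whether chloro on the carbon that carries bromo in compound 3, or bromo on the carbon that carries chloro in compound 2, would follow the halogen or the place. They also leave open how a methoxy group, a nitrile or an amine would read on the carbon that carries bromo in compound 3.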